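A few compounds are considered here, and "the series" means these few. Any claim that something is new, unique, unknown or untested is made for them only; others in the source may bear on it.

Series notes. Compound 1 `O=C(Nc1ccccc1)Nc1nnc(Sc2ncnc3scc(-c4ccncc4)c23)s1` serves as the reference; in a functional assay on T47D cells (Homo sapiens) for antiproliferative activity, read by MTT assay, with a stated time of 48 h (on this read-out higher numbers stand for weaker inhibition and lower numbers for stronger inhibition), compound 1 gives 23300 nM. Compound 2 `O=C(Nc1cccc(C(F)(F)F)c1)Nc1nnc(Sc2ncnc3scc(-c4ccncc4)c23)s1`, carrying trifluoromethyl in place of hydrogen on an aromatic carbon, gives 45100 nM in this assay. The step of a 1.9-fold higher number from compound 1 to compound 2 (0.29 log units; within the scatter) lies within the scatter, so on the numbers shown compound 1 and compound 2 stand together. Compound 3 `O=C(Nc1cccc(F)c1)Nc1nnc(Sc2ncnc3scc(-c4ccncc4)c23)s1` differs from compound 1 by fluoro in place of hydrogen on an aromatic carbon. Among the measured compounds shown here, the only step bearing on this change, a 1.9-fold higher number from compound 1 to compound 2 (0.29 log units; within the scatter), stayed within the scatter, so for compound 3 a step of a 1.1-fold higher number from compound 1 to compound 3 (0.03 log units; within the scatter) is expected, nothing beyond the scatter. Compound 3 is therefore estimated at 25000 nM in this assay, ranging from 10000 nM to 60000 nM.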

Compound 3, half-maximal inhibitory concentration: 16700 nM
Beside the measured number, compound 3's estimate is 1.5-fold (0.18 log units) above it; measured number inside the range.
By their numbers in this assay, from the lowest: compounds 3, 1 and 2 (each within the scatter of the next, the first and the last beyond it).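

On the aromatic carbon meta to a large group, fluoro in place of hydrogen does not separate compound 3 from compound 1 in this assay (a 1.4-fold lower number from compound 1 to compound 3 (0.14 log units; within the scatter)). Fluoro in place of trifluoromethyl gives the first step in the series beyond the scatter (a 2.7-fold lower number from compound 2 to compound 3 (0.43 log units; beyond the scatter)), so these two groups can be told apart at this place, although neither separates from hydrogen. No measured evidence accounts for this step.

Going by these compounds, whether an amine, a carboxylic acid or a longer chain at this place would move the number beyond the scatter from compound 1 remains open. Also open, on these data alone, is how a change on the shared core would compare.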